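The compounds below may be only part of what the source reports. "The series", "measured", "known", "first", "only" and "open" are said of these compounds alone.

Of the compounds shown here, three sharing one core have been measured in a functional assay on HCT-8 cells (Homo sapiens) for antiproliferative activity, read by MTT assay, with a stated time of 48 h; on this read-out higher numbers stand for weaker inhibition and lower numbers for stronger inhibition. Compound 1 `C=C(c1cc(OC)c(OC)c(OC)c1)c1ccc(OC)cc1NC(=O)CN(C)C` gives 340 nM, compound 2 `C=C(c1cc(OC)c(OC)c(OC)c1)c1ccc(OC)c(O)c1NC(C)=O` gives 340 nM, and compound 3 `C=C(c1cc(OC)c(OC)c(OC)c1)c1ccc(OC)c(O)c1NC(=O)COCC` gives 910 nM, the highest number of the three. Compound 4 `C=C(c1cc(OC)c(OC)c(OC)c1)c1ccc(OC)c(O)c1NC(=O)CN(C)C` has not yet been measured and differs from compound 3 by a single change on a saturated chain carbon bound to a carbonyl carbon: dimethylamino in place of ethoxy on a saturated chain carbon bound to a carbonyl carbon. In words, dimethylamino takes the place of ethoxy. Going by the values given here, no measured step exchanges these two groups directly. The nearest evidence is a 2.7-fold higher number from compound 2 to compound 3 (0.43 log units; beyond the scatter), a modest step that put ethoxy in place of hydrogen at that same place. Compound 1 carries the same dimethylamino group but has no hydroxy group, and it reads 340 nM. A modest fall in the number in this assay is therefore expected, similar in size to the step from ethoxy's arrival, though in the opposite direction. The expected change is a 2.8-fold lower number from compound 3 to compound 4 (0.45 log units; beyond the scatter). For compound 4 the estimated value is 320 nM, with an expected range from 100 nM to 1000 nM.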

Compound 4, half-maximal inhibitory concentration: 110 nM
Beside the measured number, compound 4's estimate is 2.9-fold (0.46 log units) above it; the range from low to high includes it.
By their numbers in this assay, from the lowest: compound 4; then compounds 1 and 2 (each within the scatter of the next); then compound 3.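

In this assay, the step from ethoxy to dimethylamino on a saturated chain carbon bound to a carbonyl carbon is an 8.3-fold lower number from compound 3 to compound 4 (0.92 log units; beyond the scatter), so this place separates two groups with matching counts of heavy atoms, hydrogen-bond donors and hydrogen-bond acceptors. Against hydrogen at the same place, ethoxy raised the number, whereas dimethylamino gives a 3.1-fold lower number from compound 2 to compound 4 (0.49 log units; beyond the scatter), so the direction of the change depends on the group that enters. With dimethylamino in place, hydroxy in place of hydrogen on an aromatic carbon gives a 3.1-fold lower number from compound 1 to compound 4 (0.49 log units; beyond the scatter), which shows that this group and the hydroxy group occur together in the lowest number of the set. Nothing available explains these differences. Going by these compounds, whether a diethylamino group, a primary amine or a carboxylic acid at this place would follow dimethylamino or ethoxy remains open, and so does whether the hydroxy step would hold with ethoxy on the chain.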